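Carbonyl substituent change from compound 2 to compound 3

This account rests on a few compounds, and the source may have more. Where it says the series, first, only, none or still open, it means among the compounds named here.

Two compounds of this series carry a measured value. Compound 1 `O=C(C1CC1)N1CCN(Cc2nc3ccccc3n2Cc2ccccc2C(F)(F)F)CC1` in an assay on isolated protein for inhibition of aldehyde dehydrogenase 1A1 (Homo sapiens), read by spectrophotometry, tested at 10 uM (a higher number here means more inhibition at the concentration tested (going by the name of the read-out), a lower number less inhibition), gives 56.3%. Compound 2 `CC(=O)N1CCN(Cc2nc3ccccc3n2Cc2cccc(C)c2)CC1` in this assay gives 70.3%, the highest of the two numbers; compound 1 is the nearest and stands lower by a margin beyond the usual scatter. The two compounds differ in more than one place, so no single step can be read from them.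

Compound 3 `Cc1cccc(Cn2c(CN3CCN(C(=O)c4ccc(F)cc4)CC3)nc3ccccc32)c1` has not yet been measured in this assay. Relative to compound 2 it differs as follows: 4-fluorophenyl in place of methyl on a carbonyl carbon. Within the data shown here, no measured pair in this set isolates a change of this kind, so the expectation rests on compound 2 alone. Compound 3 is expected to give 62%, with a range from 38% to 84%. The expected step of a number 8.3 percentage points lower from compound 2 to compound 3 (within the scatter) is small, within the scatter or a mild decrease.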

Compound 3, a percentage reported as inhibition, at one concentration (the size of the read-out at that concentration, not a potency): 27.1%
Beside the measured number, compound 3's estimate is 34.9 percentage points above it, and the stated range ends above it.
By their numbers in this assay, from the lowest: compound 3; then compound 1; then compound 2.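

In this assay, among these compounds, the carbonyl carbon proves to be a sensitive position: 4-fluorophenyl in place of methyl gives a number 43.2 percentage points lower from compound 2 to compound 3 (beyond the scatter), the first change that can be read at a single place. Of the two groups tested on this otherwise unchanged scaffold, the acetyl of compound 2 retains clearly more inhibition than the (4-fluorophenyl)carbonyl of compound 3. No measurement available here bears on the reason for this loss.

Among the compounds shown here, this one step cannot separate the contributions of the aromatic ring, the fluorine and the larger group, and compound 1 differs from the other two in more than one place, so no steps to it can be read. From the compounds shown here alone, an unsubstituted phenyl, a longer alkyl chain or an amine on the carbonyl carbon remains open.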